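The source may hold more compounds than are shown below. What is called first, only, known or untested is meant among the compounds shown, and "the series" means these compounds.

Working notes on the series. Compound 1 `Cc1c(Cc2ccc(F)cc2)c(=O)oc2cc(OCC(O)CN3CCC(C(N)=O)CC3)ccc12` gives in an ADME assay on A549 cells (Homo sapiens) for cytotoxicity, read by CellTiter-Glo (a higher number here means that more compound is tolerated, a lower number that less compound is tolerated), a value of 89300 nM. For compound 2 `Cc1c(Cc2ccc(F)cc2F)c(=O)oc2cc(OCC(O)CN3CCC(C(N)=O)CC3)ccc12` this assay reports only a limit, > 100000 nM. For compound 3 `Cc1c(Cc2ccc(-c3ccccc3)cc2)c(=O)oc2cc(OCC(O)CN3CCC(C(N)=O)CC3)ccc12` this assay also reports only a limit, > 100000 nM. The change from compound 1 to compound 2 is fluoro in place of hydrogen on an aromatic carbon, and the step it made is an at least 1.1-fold higher number from compound 1 to compound 2 (0.04 log units; that floor lies within the scatter). The cores of compound 1 and compound 3 differ by phenyl in place of fluoro on an aromatic carbon, with the step of an at least 1.1-fold higher number from compound 1 to compound 3 (0.04 log units; that floor lies within the scatter); the step that the two limits leave unreadable from compound 2 to compound 3 cannot be sized because two values sit at the limit of > 100000 nM in this assay, at which 2 of the 3 values shown sit.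

Compound 4 `Cc1c(Cc2ccc(-c3ccc(F)cc3)cc2)c(=O)oc2cc(OCC(O)CN3CCC(C(N)=O)CC3)ccc12` carries the same kind of change as compound 2, namely (fluoro in place of hydrogen on an aromatic carbon), here para to a large group rather than ortho to a large group and meta to a fluoro group. The expected step is a step that the limit leaves unreadable from compound 3 to compound 4, resting on the step of an at least 1.1-fold higher number from compound 1 to compound 2 (0.04 log units; that floor lies within the scatter), which did not lower the tolerated concentration. Compound 4 is estimated at 150000 nM in this assay.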

Compound 4, half-maximal cytotoxic concentration: 19300 nM
Estimate against measurement, compound 4: 7.8-fold (0.89 log units) above; the whole stated range lies above it.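

In this assay, fluoro in place of hydrogen on an aromatic carbon gives an at least 5.1-fold lower number from compound 3 to compound 4 (0.71 log units; beyond the scatter), and 4-fluorophenyl in place of fluoro gives a 4.6-fold lower number from compound 1 to compound 4 (0.67 log units; beyond the scatter). The same change therefore does not carry over as one step between these two cores: the same change on two cores in this assay, an at least 1.1-fold higher number (0.04 log units; that floor lies within the scatter) from compound 1 to compound 2 and an at least 5.1-fold lower number (0.71 log units; beyond the scatter) from compound 3 to compound 4, at least 5.8-fold (0.76 log units) apart, beyond the scatter of two such steps. This does not show the true size of either fluoro step, as each is only a floor set by a limit of the assay: the limit of > 100000 nM in this assay, at which 2 of the 4 values shown sit.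

As far as these compounds go, whether the lower number is particular to the 4-fluorophenyl group remains open. Also open, from the compounds shown here alone, is what a chloro or methoxy group in place of that fluoro would give.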